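Swapping the Aryl Amide Substituent on a Shared Core

The source may report more compounds than this note shows. Statements on the series, on what has been measured and on what is new or still open speak of the compounds shown alone.

Compound 1 `CN(C(=O)C(C)(C)C)c1ccc2[nH]c(-c3n[nH]c4ccccc34)cc2n1` gives 24400 nM in a functional assay on A549 cells (Homo sapiens) for antiproliferative activity, read by MTT assay, with a stated time of 72 h; on this read-out higher numbers stand for weaker inhibition and lower numbers for stronger inhibition.
Compound 2 `CN(C(=O)c1ccccc1)c1ccc2[nH]c(-c3n[nH]c4ccccc34)cc2n1` gives 13800 nM.
Compound 3 `CN(C(=O)c1ccc(F)cc1)c1ccc2[nH]c(-c3n[nH]c4ccccc34)cc2n1` gives 9650 nM.

Compound 3 sits at the low end of these three numbers. Its gap to compound 2, a 1.4-fold lower number from compound 2 to compound 3 (0.16 log units; within the scatter), is within the scatter, so the two cannot be told apart, while its gap to compound 1, a 2.5-fold lower number from compound 1 to compound 3 (0.40 log units; beyond the scatter), is beyond it.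

Compound 4 `COc1cccc(C(=O)N(C)c2ccc3[nH]c(-c4n[nH]c5ccccc45)cc3n2)c1` differs from compound 3 by 3-methoxyphenyl in place of 4-fluorophenyl on a carbonyl carbon. Within the data shown here, the steps that bear on this are those that already varied the group on the carbonyl carbon: a 1.8-fold lower number from compound 1 to compound 2 (0.25 log units; within the scatter) and a 1.4-fold lower number from compound 2 to compound 3 (0.16 log units; within the scatter), both within the scatter, and only a 2.5-fold lower number from compound 1 to compound 3 (0.40 log units; beyond the scatter) reached a modest size. Among the measured compounds shown here, nothing measured so far carries a methoxy group, so the new substituent itself is untested. Given that aryl groups on this carbonyl carbon have moved the number little, the expected step is a 1.2-fold higher number from compound 3 to compound 4 (0.09 log units; within the scatter), no larger than the scatter in either direction. The estimate for compound 4 is 12000 nM, with an expected range from 5000 nM to 30000 nM.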

Compound 4, half-maximal inhibitory concentration: 14900 nM
Compound 4: the middle estimate sits 1.2-fold (0.09 log units) below what was measured, and the stated range covers the measured number.
By their numbers in this assay, from the lowest: compounds 3, 2, 4 and 1 (each within the scatter of the next, the first and the last beyond it).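

The 3-methoxyphenyl group puts the first oxygen on this aryl ring and the first hydrogen-bond acceptor on this part of the molecule, yet the number in this assay barely responds: the exchange for 4-fluorophenyl gives a 1.5-fold higher number from compound 3 to compound 4 (0.19 log units; within the scatter) and adding methoxy to the plain phenyl gives a 1.1-fold higher number from compound 2 to compound 4 (0.03 log units; within the scatter). Replacing tert-butyl gives a 1.6-fold lower number from compound 1 to compound 4 (0.21 log units; within the scatter), so compound 4, unlike compound 3, cannot be told apart from compound 1. No measurement shown here offers an explanation for these small steps.

Still open, on these data alone, is whether a different kind of group on this carbonyl carbon, such as an aryl ring carrying an amine or a carboxylic acid, or a longer alkyl chain, would move the number beyond the scatter. As far as these compounds go, the effect of putting hydrogen in place of the methyl on the amide-type nitrogen also remains unknown.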